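The compounds below may be only part of what the source reports. "The series", "measured", "known", "first", "only" and "open" are said of these compounds alone.

Compound 1 `COc1ccc(C23CCC(=O)N2CCCO3)cc1` gives 139 mg/kg in a functional assay on the whole organism with Mus musculus as the target; a lower number here means that less compound is needed, a higher number that more compound is needed for the effect.
Compound 2 `O=C(CCC(=O)c1ccc(Cl)c(Cl)c1)NCCCO` gives only the limit > 600 mg/kg in this assay.
Compound 3 `COc1ccc(C(=O)CCC(=O)NCCCO)cc1` gives only the limit > 600 mg/kg in this assay.

Going by the values given here, of these three, compound 1 is the only one with a measured number. The two other readings are limits, not numbers, described as the limit of > 600 mg/kg in this assay, at which 2 of the 3 values shown sit. Among the compounds with values here, no step between two measured compounds is available, so the change toward compound 4 has no measured neighbour to lean on. Compound 4 `O=C1CCC2(c3ccccc3)OCCCN12` differs from compound 1 by hydrogen in place of methoxy on an aromatic carbon. The change is small in size, and a step of no more than the usual scatter is expected in this assay, in either direction. Compound 4 is therefore estimated at 150 mg/kg, with a range from 70 mg/kg to 350 mg/kg. The step of a 1.1-fold higher number from compound 1 to compound 4 (0.03 log units; within the scatter) that this estimate means is expected to stay within the scatter.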

Compound 4, dose for half-maximal effect: 169 mg/kg
Estimate against measurement, compound 4: 1.1-fold (0.05 log units) below, and the stated range covers the measured number.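

Hydrogen in place of methoxy on the aromatic carbon gives a 1.2-fold higher number from compound 1 to compound 4 (0.08 log units; within the scatter) in this assay. Going by these compounds alone, this is the first measured step in the set, and it shows that the methoxy group can go from this position without a change beyond the scatter. Nothing shown here bears on why the step is so small.

Still open, going by these compounds, is whether any group at this position moves the number, for example an amine or a carboxylic acid. On these data alone, the other positions on the aromatic ring also remain untested by a single change.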